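The source may report more compounds than this note shows. Statements on the series, on what has been measured and on what is new or still open speak of the compounds shown alone.

Of the compounds shown here, two have numbers so far. Compound 1 `O=C(/C=C/c1ccc(Cn2cc(Nc3ncc(Cl)c(Nc4ccc(F)cc4)n3)cn2)cc1)NO` gives 150 nM in a functional assay on Jurkat cells (Homo sapiens) for antiproliferative activity, read by MTT assay, with a stated time of 48 h; on this read-out lower numbers stand for stronger inhibition and higher numbers for weaker inhibition. Compound 2 `O=C(CCCCCCn1cc(Nc2ncc(Cl)c(Nc3cccc(Cl)c3)n2)cn1)NO` gives 100 nM in this assay, the lowest of the two numbers shown, though its gap to compound 1 sits within the scatter. Compound 3 `COc1ccc(Nc2nc(Nc3cnn(CCCCCCC(=O)NO)c3)ncc2Cl)cc1` remains to be measured; it differs from compound 2 by 4-methoxyphenyl in place of 3-chlorophenyl on a nitrogen on an aromatic ring. Within the data shown here, no single-site step among the measured compounds bears on this change, so only a small shift, if any, is expected, namely a 1.5-fold higher number from compound 2 to compound 3 (0.18 log units; within the scatter). Compound 3 is estimated at 150 nM, with a range from 60 nM to 400 nM.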

Compound 3, half-maximal inhibitory concentration: 130 nM
Estimate against measurement, compound 3: 1.2-fold (0.06 log units) above; the measured number falls inside the stated range.
By their numbers in this assay, from the lowest: compounds 2, 3 and 1 (each within the scatter of the next).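

In this assay, 4-methoxyphenyl in place of 3-chlorophenyl on a nitrogen on an aromatic ring gives a 1.3-fold higher number from compound 2 to compound 3 (0.11 log units; within the scatter) and so leaves the number within the scatter. Among these compounds, this is the first single-site step, and it shows that this position accepts a change in both the substituent and its place on the phenyl ring without a shift beyond the scatter. Nothing on hand bears on why these two groups read alike.

Still open, as far as these compounds go, is whether a cyclohexyl group or an aminophenyl group on this nitrogen moves the number beyond the scatter. Also open, from the compounds shown here alone, is whether the same change reads alike with the linker of compound 1.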